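Methoxy-to-hydroxy step on a second urea core

The compounds below may be only part of what the source reports. "The series", "measured", "known", "first", "only" and "open" are said of these compounds alone.

Measured compounds:
compound 1, `COc1cc(-c2nn(-c3cccc(NC(=O)Nc4cc(C(F)(F)F)cc(C(F)(F)F)c4)c3)cc2-c2ccncc2)ccc1Cl`: 2020 nM
compound 2, `O=C(Nc1cccc(-n2cc(-c3ccncc3)c(-c3ccc(Cl)c(O)c3)n2)c1)Nc1cc(C(F)(F)F)cc(C(F)(F)F)c1`: 3160 nM
compound 3, `COc1cc(-c2nn(-c3cccc(NC(=O)Nc4ccc(Cl)c(C(F)(F)F)c4)c3)cc2-c2ccncc2)ccc1Cl`: 8020 nM

In a functional assay on 786-0 cells (Homo sapiens) for inhibition, read by sulforhodamine B assay, with a stated time of 48 h (a higher number here means a weaker inhibitor of growth, a lower number a stronger inhibitor of growth), compound 1 gives 2020 nM. The change hydrogen in place of methyl on an oxygen on an aromatic ring leads to compound 2, and in this assay compound 2 gives 3160 nM; the step of a 1.6-fold higher number from compound 1 to compound 2 (0.19 log units; within the scatter) is small and cannot be told from noise.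

Compound 3 carries a different core; the difference between the core of compound 1 and the core of compound 3 is not broken down here. In this assay compound 3 gives 8020 nM, the highest number of the three, beyond the scatter from both compound 1 and compound 2.

Compound 4, `O=C(Nc1cccc(-n2cc(-c3ccncc3)c(-c3ccc(Cl)c(O)c3)n2)c1)Nc1ccc(Cl)c(C(F)(F)F)c1`, is not yet measured. It arises from compound 3 by the change (hydrogen in place of methyl on an oxygen on an aromatic ring), the same change seen from compound 1 to compound 2: the place line reads the same word for word, an oxygen on an aromatic ring whose other neighbours are aromatic carbon, and the wider reading is again methoxy to hydroxy on the 4-chloro-3-methoxyphenyl group.

Among the compounds with values here, only one earlier instance of the change is known, and it sits on the other core, so the expectation for compound 4 rests on the single step of a 1.6-fold higher number from compound 1 to compound 2 (0.19 log units; within the scatter) alone. Compound 4 is expected to move by about a 1.5-fold higher number from compound 3 to compound 4 (0.18 log units; within the scatter), a step of similar size and direction to the earlier one, because the earlier step of a 1.6-fold higher number from compound 1 to compound 2 (0.19 log units; within the scatter) stayed within the scatter. Compound 4 is thus estimated at 12000 nM, with a plausible range from 5000 nM to 30000 nM.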

Compound 4, concentration for total growth inhibition: > 32500 nM
Compound 4: only a limit was reported (the forecaster's own chance of this, stated with the estimate: 10%); middle value at least 2.7-fold (0.43 log units) from the limit.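

The change from methoxy to hydroxy gives an at least 4.0-fold higher number from compound 3 to compound 4 (0.60 log units; beyond the scatter) in this assay, against a 1.6-fold higher number from compound 1 to compound 2 (0.19 log units; within the scatter) on the other core. Compound 4 reads > 32500 nM in this assay, which is a limit of the assay and not a number, and it is the only such limit among the compounds shown: the limit of > 32500 nM in this assay, at which 1 of the 4 values shown sits. The result shows that a step within the scatter on one core gave no assurance of the same on the other core, but it does not show that the two steps truly differ, and two cores are too few to support a rule for the series: the same change on two cores in this assay, a 1.6-fold higher number (0.19 log units; within the scatter) from compound 1 to compound 2 and an at least 4.0-fold higher number (0.60 log units; beyond the scatter) from compound 3 to compound 4; the limit leaves it open whether they differ.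

Going by these compounds, the true size of the step on the second core stays open, as does whether the change would read the same on any further core or with other groups on the urea. Also open, on these data alone, is how other replacements for the methoxy group on the 4-chloro-3-methoxyphenyl group would read on these cores, for example an ethoxy group, an amine or a carboxylic acid.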